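The source may hold more compounds than are shown below. What is called first, only, known or untested is meant among the compounds shown, and "the series" means these compounds.

Measured in an assay on CHO cells for displacement of a labelled ligand from adenosine receptor A3 (Homo sapiens), read by scintillation counting, with a stated time of 120 min, tested at 1 uM; on this read-out lower numbers stand for less inhibition and higher numbers for more inhibition at the one concentration tested (going by the name of the read-out): compound 1 `COc1cccc(-c2nc3c(=O)[nH]c(C)nc3s2)c1` gives 28%, compound 2 `Cc1nc2sc(-c3cccnc3)nc2c(=O)[nH]1` gives 33%, and compound 3 `CCOc1nc(C)nc2sc(-c3ccccc3)nc12` gives 6%.

Compound 3 stands lowest of these three numbers. Its nearest neighbour is compound 1, whose number is higher by more than the usual scatter, and compound 2 stands further away, also beyond the scatter.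

Compound 4 `CCOc1nc(C)nc2sc(-c3ccc(Cl)cc3)nc12` differs from compound 3 by one change: chloro in place of hydrogen on an aromatic carbon. Among the compounds with values here, no two of the measured compounds differ from each other in only one place, so no measured step shows what such a change does here. The expected step in this assay is small, at most a slight rise, and likely within the scatter. For compound 4 the estimated value is 12%, with a range from 0% to 32%, an expected step of a number 6 percentage points higher from compound 3 to compound 4 (within the scatter).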

Compound 4, a percentage reported as inhibition, at one concentration (the size of the read-out at that concentration, not a potency): 10%
The estimate for compound 4 lay 2 percentage points above the measured number, within the range that was stated.
By their numbers in this assay, from the lowest: compounds 3 and 4 (each within the scatter of the next); then compounds 1 and 2 (each within the scatter of the next).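

Chloro in place of hydrogen on an aromatic carbon, para to a large group, gives a number 4 percentage points higher from compound 3 to compound 4 (within the scatter) in this assay, the first step here between compounds that differ in one place. At this position, then, the chloro group leaves the reading indistinguishable from that of the hydrogen compound. No supporting data are available to explain this result. From the compounds shown here alone, whether an amine or a carboxylic acid at the same carbon would shift the reading stays open. So does whether chloro would behave alike on another carbon of that ring.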